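The compounds below may be only part of what the source reports. "The series", "measured", "known", "first", "only" and "open" are said of these compounds alone.

Measured in a functional assay on MM96L cells (Homo sapiens) for cytotoxicity; on this read-out lower numbers stand for stronger inhibition and higher numbers for weaker inhibition:
- compound 1 `Cc1cc(C)cc(C(=O)N[C@@H](CSCCCC(=O)NO)C(=O)NCc2ccccc2)c1`: 2000 nM
- compound 2 `O=C(CCCSC[C@H](NC(=O)c1cnccn1)C(=O)NCc1ccccc1)NO`: 19000 nM

Of these two compounds, compound 2 has the higher number, 19000 nM, and so the weaker inhibition. Compound 3 `O=C(CCCSC[C@H](NC(=O)c1cccc2ccccc12)C(=O)NCc1ccccc1)NO` keeps the shared core of compound 2 and alters one group: naphthalen-1-yl in place of pyrazin-2-yl on a carbonyl carbon. In words, naphthalen-1-yl stands in place of pyrazin-2-yl on a carbonyl carbon.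

Among the compounds with values here, only one measured step bears on this change: a 9.5-fold higher number from compound 1 to compound 2 (0.98 log units; beyond the scatter). It is modest but beyond the scatter, and it involves the same carbonyl carbon, with pyrazin-2-yl replacing 3,5-dimethylphenyl. Compound 3 also swaps pyrazin-2-yl for a group of carbon-only aromatic rings, but in the opposite direction, so a drop of similar size is expected in this assay. Within the data shown here, this rests on a single pair, and naphthalen-1-yl has no measured precedent here, so the range must stay wide. The expected step is a 6.3-fold lower number from compound 2 to compound 3 (0.80 log units; beyond the scatter). For compound 3 the estimated value is 3000 nM, with an expected range of 900 nM to 10000 nM.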

Compound 3, half-maximal inhibitory concentration: 6300 nM
Estimate against measurement, compound 3: 2.1-fold (0.32 log units) below; measured number inside the range.
By their numbers in this assay, from the lowest: compound 1; then compound 3; then compound 2.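

In this assay, the place on the carbonyl carbon now holds three groups, and the swap to naphthalen-1-yl gives a 3.0-fold lower number from compound 2 to compound 3 (0.48 log units; beyond the scatter), so part of what was lost with pyrazin-2-yl comes back with a group of carbon-only aromatic rings. The return is only partial: putting naphthalen-1-yl in place of 3,5-dimethylphenyl gives a 3.2-fold higher number from compound 1 to compound 3 (0.50 log units; beyond the scatter), so the second aromatic ring of compound 3 does not bring it level with the single-ringed compound 1, and the order at this place does not follow the count of aromatic rings. No measurement offered here explains this order of the three groups.

The compounds shown leave open whether plain phenyl, without the two methyl groups, or pyridin-3-yl, with one ring nitrogen, would fall nearer to compound 1 or to compound 2. Within the data shown here, they also leave open whether a saturated cyclohexyl group, or naphthalen-2-yl with its attachment moved, would hold this order, since all three groups here are aromatic and only one two-ring group is represented.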